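The source may hold more compounds than are shown below. What is called first, only, known or untested is meant among the compounds shown, and "the series" means these compounds.

Compound 1 `COc1ccc(Cc2nnc3n2NC(c2ccco2)S3)cc1OC`: 24.6%
Compound 2 `Cc1occc1-c1nnc2n1NC(c1ccc([N+](=O)[O-])o1)S2`: 24.9%
Compound 3 `Cc1occc1-c1nnc2n1NC(c1ccc[nH]1)S2`: 22.7%

In a functional assay on the whole organism (strain Wistar Albino) for inhibition, with Rattus norvegicus as the target, read by paw edema, with a stated time of 4 h, at a dose of 20 mg/kg (on this read-out lower numbers stand for less inhibition and higher numbers for more inhibition at the one dose given (going by the name of the read-out)), compound 1 gives 24.6%, the second highest of the three numbers shown. Compound 2 gives 24.9%, within the scatter of compound 1, and compound 3 gives 22.7%, also within the scatter of compound 1. The three numbers are thus indistinguishable by this read-out.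

Compound 4 `COc1ccc(Cc2nnc3n2NC(c2cccn2C)S3)cc1OC` has not yet been measured. It differs from compound 1 in one place: 1-methyl-1H-pyrrol-2-yl in place of furan-2-yl on a saturated ring carbon. Among the compounds with values here, no pair of measured compounds that differ in one place is available, so no step of this kind is known. All three measured numbers sit within the scatter of each other, and no step beyond the scatter is expected in this assay for compound 4 either.

Compound 4 is estimated to give 24%, with a range from 14% to 34%. The expected step of a number 0.6 percentage points lower from compound 1 to compound 4 (within the scatter) is estimated to stay within the scatter.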

Compound 4, a percentage reported as inhibition, in the whole organism at one dose (the size of the read-out at that dose, not a potency): 19.9%
The estimate for compound 4 lay 4.1 percentage points above the measured number; measured number inside the range.
By their numbers in this assay, from the lowest: compounds 4, 3, 1 and 2 (each within the scatter of the next).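

Within the data shown here, the first one-place step at this position, measured in this assay, is a number 4.7 percentage points lower from compound 1 to compound 4 (within the scatter). With 1-methyl-1H-pyrrol-2-yl in place of furan-2-yl on the saturated ring carbon, the position accepts this exchange of one five-membered aromatic ring for another with no step beyond the scatter. No available data bear on the reason for this result.

On these data alone, whether an amine, a carboxylic acid or a longer alkyl chain at this carbon would give a step beyond the scatter remains open. A plain phenyl ring there is equally unresolved.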